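Ester to alcohol on the shared core of compound 2

The source may hold more compounds than are shown below. What is called first, only, known or untested is meant among the compounds shown, and "the series" means these compounds.

Of the compounds shown here, three have been measured in a functional assay on JeKo-1 cells (Homo sapiens) for inhibition, read by luminescence and CellTiter-Glo, with a stated time of 72 h; on this read-out lower numbers stand for stronger inhibition and higher numbers for weaker inhibition. Compound 1 `C/C=C/C(=O)N1CCCC(n2nc(-c3ccc(Oc4ccccc4)cc3)cc2C(=O)OCC)C1` gives 26500 nM, compound 2 `C=CC(=O)N1CCCC(n2nc(-c3ccc(Oc4ccccc4)cc3)cc2C(=O)OCC)C1` gives 21200 nM, and compound 3 `C/C=C/C(=O)Nc1ccc(Cn2nc(-c3ccc(Oc4ccccc4)cc3)cc2C(=O)OCC)cc1` gives 52500 nM. Compound 2 stands at the lowest of these three numbers; its distance from compound 1 is a 1.3-fold lower number from compound 1 to compound 2 (0.10 log units; within the scatter), so the two cannot be ordered, while compound 3 gives a higher number than compound 2 by a margin beyond the scatter.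

Compound 4 `C=CC(=O)N1CCCC(n2nc(-c3ccc(Oc4ccccc4)cc3)cc2CO)C1` is not yet measured. It differs from compound 2 in one place: hydroxymethyl in place of ethoxycarbonyl on an aromatic carbon. Among the compounds with values here, no measured step in the set alters this position; the only step on record, from compound 1 to compound 2, concerns the group on the carbonyl carbon of the amide, and it was within the scatter. There is therefore nothing in the data that points to a direction for the ester-to-alcohol exchange, and the working expectation is a step of a 1.1-fold lower number from compound 2 to compound 4 (0.03 log units; within the scatter), with a wide range to reflect the absence of any comparable step. On that basis compound 4 is estimated to give 20000 nM in this assay, between 5000 nM and 80000 nM.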

Compound 4, half-maximal inhibitory concentration: 11900 nM
Compound 4: middle estimate off by 1.7-fold (0.23 log units), on the high side; the range from low to high includes it.
By their numbers in this assay, from the lowest: compounds 4, 2, 1 and 3 (each within the scatter of the next, the first and the last beyond it).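

In this assay, within the data shown here, this is the first step read at this position, and the exchange of ethoxycarbonyl for hydroxymethyl, a 1.8-fold lower number from compound 2 to compound 4 (0.25 log units; within the scatter), lies within the scatter, so the two compounds cannot be ordered. The position on the aromatic carbon therefore accepts a much smaller group: ethoxycarbonyl, with 5 heavy atoms and no hydrogen-bond donor, gives way to hydroxymethyl, with 2 heavy atoms and 1 hydrogen-bond donor, with no difference that can be read in this assay. Nothing on hand explains the size of this step or tells which part of the ethoxycarbonyl group could matter here.

The compounds shown leave open whether a carboxylic acid, an aminomethyl group or a longer chain such as 2-hydroxyethyl on this aromatic carbon would give a number beyond the scatter from that of compound 4. They also leave open whether the same exchange would give a step of similar size with prop-1-en-1-yl on the carbonyl carbon, as in compound 1, or on the scaffold of compound 3.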